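The source may hold more compounds than are shown below. What is called first, only, known or untested is meant among the compounds shown, and "the series" means these compounds.

Measured so far:
- compound 1 `O=S(=O)(c1ccccc1)c1nc2ccccc2nc1N1CCCC1`: 3460 nM
- compound 2 `COc1ccc(S(=O)(=O)c2nc3ccccc3nc2N2CCCC2)cc1`: 16000 nM

Among the measured compounds shown here, in a functional assay on HL-60 cells (Homo sapiens) for cytotoxicity, read by MTT assay, with a stated time of 72 h (a higher number here means a weaker inhibitor, a lower number a stronger inhibitor), compound 2 gives 16000 nM, the higher of the two numbers, and its only neighbour, compound 1, gives 3460 nM. The next compound to be tested is compound 3 `O=S(=O)(c1ccc(Br)cc1)c1nc2ccccc2nc1N1CCCC1`, which keeps the shared core and differs from compound 2 at one place: bromo in place of methoxy on an aromatic carbon. Put simply, the 4-methoxyphenyl of compound 2 becomes the 4-bromophenyl of compound 3.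

For the measured compounds named here, only one measured step bears on this change: a 4.6-fold higher number from compound 1 to compound 2 (0.67 log units; beyond the scatter), where methoxy took the place of hydrogen. Going by the values given here, no compound with bromo has been measured, so how bromo compares with hydrogen is unknown. Compound 3 no longer carries the methoxy, so, going by that single modest step, a step of similar or somewhat smaller size in the opposite direction is expected in this assay, towards a lower number. The expected change is a 3.2-fold lower number from compound 2 to compound 3 (0.51 log units; beyond the scatter). Compound 3 is estimated at 5000 nM, with an expected range from 1500 nM to 14000 nM.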

Compound 3, half-maximal inhibitory concentration: 6070 nM
Estimate against measurement, compound 3: 1.2-fold (0.08 log units) below, within the range that was stated.
By their numbers in this assay, from the lowest: compounds 1 and 3 (each within the scatter of the next); then compound 2.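

In this assay, the exchange of methoxy for bromo on this aromatic carbon gives a 2.6-fold lower number from compound 2 to compound 3 (0.42 log units; beyond the scatter), so the higher number of the methoxy compound falls when that group is replaced by a single bromine atom as well as when it is replaced by hydrogen. The comparison of bromo with hydrogen, unavailable until now, gives a 1.8-fold higher number from compound 1 to compound 3 (0.24 log units; within the scatter); that step lies within the scatter, so this assay does not separate the two groups, and among the three groups tested here only methoxy stands apart, with both of its steps beyond the scatter. Nothing measured here offers an explanation for why methoxy differs from the other two groups.

Three groups at one place cannot show whether the higher number belongs to methoxy alone or would also appear with ethoxy, hydroxy, an amine or a carboxylic acid on the same carbon. On these data alone, it also remains open whether a group such as nitrile or trifluoromethyl at this place would clearly move the number away from that of compound 1 , which gives 3460 nM, in either direction.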